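Methoxy in place of trifluoromethyl on compound 2

The source may report more compounds than this note shows. Statements on the series, on what has been measured and on what is new or still open speak of the compounds shown alone.

Values in a physicochemical assay for solubility, measured as kinetic solubility; a lower number here means a less soluble compound, a higher number a more soluble compound:
- compound 1 `Cc1n[nH]c(-c2ncc3c(-c4ccccc4)ccnc3c2O)n1`: 160000 nM
- compound 2 `Cc1n[nH]c(-c2ncc3c(-c4ccccc4C(F)(F)F)ccnc3c2O)n1`: > 250000 nM (a limit, not a number)

Compound 2 stands at the limit of > 250000 nM in this assay, at which 1 of the 2 values shown sits, and so has no exact number. Compound 3 `COc1ccccc1-c1ccnc2c(O)c(-c3nc(C)n[nH]3)ncc12` has methoxy in place of trifluoromethyl on an aromatic carbon and keeps the shared core. Within the data shown here, the one measured step that bears on this is an at least 1.5-fold higher number from compound 1 to compound 2 (0.19 log units; that floor lies within the scatter) and it concerns trifluoromethyl only, with its floor within the scatter. Compound 1 at 160000 nM is the nearest true number, so a modest drop in this assay is expected. an at least 1.3-fold lower number from compound 2 to compound 3 (0.14 log units; that floor lies within the scatter) is the estimated size of that drop. Compound 3 is estimated at 180000 nM with an expected range from 90000 nM to 250000 nM overall.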

Compound 3, solubility: > 250000 nM
Compound 3 was reported as a limit; the forecaster's own chance of this, stated with the estimate: 15%; middle value at least 1.3-fold (0.14 log units) away from the limit.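

Methoxy in place of hydrogen on this aromatic carbon, ortho to a large group, gives an at least 1.5-fold higher number from compound 1 to compound 3 (0.19 log units; that floor lies within the scatter) in this assay. Compound 3 reads > 250000 nM, which is a limit and not a number. The step between compound 2 and compound 3 cannot be read, so trifluoromethyl and methoxy, the latter with a hydrogen-bond acceptor and the former with none, stand unranked at one limit: the limit of > 250000 nM in this assay, at which 2 of the 3 values shown sit.

Open, going by these compounds, is how the two groups rank against each other in this assay. Also open, on these data alone, is whether an amine or a carboxylic acid on this carbon would give a true number there.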